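The source may report more compounds than this note shows. Statements on the series, on what has been measured and on what is new or still open speak of the compounds shown alone.

Measured compounds:

Compound 1 `Cc1cc(NC(=O)c2ccc(Cl)cc2)ccc1NS(=O)(=O)C(F)(F)F` gives 201000 nM.
Compound 2 `COc1cc(NC(=O)c2ccc(Cl)cc2)ccc1NS(C)(=O)=O` gives > 250000 nM, which is a limit of the assay rather than a number.
Compound 3 `CCS(=O)(=O)Nc1ccc(NC(=O)c2ccc(Cl)cc2)cc1OC` gives > 250000 nM, likewise a limit and not a number.

All three were tested in an ADME assay on HEK293 cells (Homo sapiens) for cytotoxicity, read by MTT assay, with a stated time of 48 h; a higher number here means a weaker inhibitor, a lower number a stronger inhibitor. Compound 3 stands only at a limit there, and one further value among the three is also a limit. Among the measured compounds shown here, the one step between neighbouring compounds, a step that the two limits leave unreadable from compound 2 to compound 3, therefore cannot be read as a size, because both of its ends sit at the limit of > 250000 nM in this assay, at which 2 of the 3 values shown sit.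

Compound 4 `COc1cc(NC(=O)c2ccc(Cl)cc2)ccc1NS(=O)(=O)C(F)(F)F` has not yet been measured in this assay. It differs from compound 3 by trifluoromethyl in place of ethyl on a sulfonyl sulfur. For the measured compounds named here, no measured step bears directly on this change. Going by the values given here, compound 1 also carries a trifluoromethyl on a sulfonyl sulfur but differs from compound 4 elsewhere in the core, so its value shows only that such a compound can return a number close to the limit.

Given that all values shown sit at or near the limit, no step beyond the usual scatter is expected from compound 3 to compound 4; the estimated step is an at least 1.1-fold lower number from compound 3 to compound 4 (0.05 log units; that floor lies within the scatter). Compound 4 is accordingly expected to give about 220000 nM, within a range from 110000 nM to 300000 nM.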

Compound 4, half-maximal inhibitory concentration: > 250000 nM
Compound 4: only a limit was reported (the forecaster's own chance of this, stated with the estimate: 50%); middle value at least 1.1-fold (0.05 log units) away from the limit.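

Placing trifluoromethyl on the sulfonyl sulfur of the methoxy compound gives no readable change in this assay, and the steps from compound 2 and from compound 3 to compound 4 cannot be read as sizes, as each compound sits at a limit of the assay: the limit of > 250000 nM in this assay, at which 3 of the 4 values shown sit. Among the compounds shown here, the one readable step is an at least 1.2-fold higher number from compound 1 to compound 4 (0.09 log units; that floor lies within the scatter) for methoxy in place of methyl on an aromatic carbon, and only its floor is known. Compound 1 is the only one of the four to return a number rather than a limit, so carrying trifluoromethyl on this sulfur is not enough on its own for a compound to return a number.

From the compounds shown here alone, it remains open whether a longer chain such as butyl, or a phenyl ring, on this sulfur would bring the methoxy compounds to a readable number. Going by these compounds, it is also open whether the methyl core with plain methyl or ethyl on the sulfur would return a number, or whether an amine on the aromatic carbon in place of methoxy would do so.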